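Extending the acid chain on a shared triaryl-methane core

This account rests on a few compounds, and the source may have more. Where it says the series, first, only, none or still open, it means among the compounds named here.

Measured so far:
Compound 1, `CCC(CC)(c1ccc(OS(=O)(=O)c2ccc(C)cc2)c(C)c1)c1ccc(OCC(O)C(C)(C)C)c(OCC(O)C(C)(C)C)c1` — 43%
Compound 2, `CCC(CC)(c1ccc(OCC(O)CO)c(C)c1)c1ccc(OCC(O)C(C)(C)C)c(OCC(O)C(C)(C)C)c1` — 78%
Compound 3, `CCC(CC)(c1ccc(OCCCCC(=O)O)c(C)c1)c1ccc(OCC(O)C(C)(C)C)c(OCC(O)C(C)(C)C)c1` — "not active" (no number reported)

All three compounds share one core and differ only in the group hanging from one oxygen on an aromatic ring. In an assay on cells for binding affinity to vitamin D3 receptor (Homo sapiens), read by fluorescence, tested at 1 uM (a higher number here means more inhibition at the concentration tested (going by the name of the read-out), a lower number less inhibition), compound 1 gives 43%, the lowest of the two numbers reported; compound 2 sits higher, and the step of a number 35 percentage points higher from compound 1 to compound 2 (beyond the scatter) shows that swapping the sulfonyl group for a small diol lifts the read-out well beyond the scatter. Compound 3 carries an acid chain and is reported in this assay as "not active" (no number reported), with no number given.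

Compound 4, `CCC(CC)(c1ccc(OCCCCCC(=O)O)c(C)c1)c1ccc(OCC(O)C(C)(C)C)c(OCC(O)C(C)(C)C)c1`, has not been measured. It differs from compound 1 as follows: 5-carboxypentyl in place of (4-methylphenyl)sulfonyl on an oxygen on an aromatic ring. For the measured compounds named here, no measured step covers exactly this change. The nearest comparison is compound 3, whose acid chain is one carbon shorter and which showed "not active" (no number reported). On that basis compound 4 is expected to lose inhibition rather than gain it, with a number 31 percentage points lower from compound 1 to compound 4 (beyond the scatter) as the estimated step. The expected value for compound 4 in this assay is 12%, most likely between 0% and 40%, and a report of no activity at all would not be surprising.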

Compound 4, a percentage reported as inhibition, at one concentration (the size of the read-out at that concentration, not a potency): "not active" (no number reported)
Compound 4 has no reported number here; the estimate stays without a comparison.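

In this assay compound 4 gives "not active" (no number reported), so no new step can be read from it, either against compound 1 or against compound 3. No evidence on the reason for this result is available. The compounds shown leave open whether any acid chain on the shared core can give a measurable number.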